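Adding fluorine to a weakly cytotoxic aryl benzothiazole

This account rests on a few compounds, and the source may have more. Where it says the series, first, only, none or still open, it means among the compounds named here.

Of the compounds shown here, three sharing one core have been tested in an ADME assay on MCF-10A cells (Homo sapiens) for cytotoxicity, read by MTT assay, with a stated time of 72 h; a lower number here means a stronger inhibitor, a higher number a weaker inhibitor. Compound 1 `COc1cc(-c2ccc(C)n2-c2ccc(-c3nc4ccccc4s3)cc2)cc(OC)c1OC` gives 38800 nM, compound 2 `COc1ccc(-c2ccc(C)n2-c2ccc(-c3nc4ccc(F)cc4s3)cc2)cc1` gives 37800 nM, and compound 3 `Cc1ccc(-c2ccc([N+](=O)[O-])cc2)n1-c1ccc(-c2nc3ccc(F)cc3s2)cc1` gives 39000 nM; all three sit within the scatter of one another, so compound 1 cannot be set apart from them. Among the measured compounds shown here, the only single-point step measured, a 1.0-fold higher number from compound 2 to compound 3 (0.01 log units; within the scatter), concerns a different position and shows no real movement. Compound 4 `COc1cc(-c2ccc(C)n2-c2ccc(-c3nc4ccc(F)cc4s3)cc2)cc(OC)c1OC` differs from compound 1 by fluoro in place of hydrogen on an aromatic carbon. Compound 2 already carries that fluoro beside a different methoxy pattern and shows much the same number as compound 1, so compound 4 is expected to change little, a 1.0-fold lower number from compound 1 to compound 4 (0.01 log units; within the scatter). The estimate for compound 4 is 38000 nM, ranging from 19000 nM to 76000 nM.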

Compound 4, half-maximal inhibitory concentration: 40000 nM
Compound 4: middle estimate off by 1.1-fold (0.02 log units), on the low side, within the range that was stated.
By their numbers in this assay, from the lowest: compounds 2, 1, 3 and 4 (each within the scatter of the next).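

Among the compounds shown here, compound 4 gives the first direct reading of fluoro against hydrogen at this position, with the rest of compound 1 unchanged: a 1.0-fold higher number from compound 1 to compound 4 (0.01 log units; within the scatter). So, in this assay, the swap from 1,3-benzothiazol-2-yl to 6-fluoro-1,3-benzothiazol-2-yl shows no real effect on this background. No supporting measurement is available to interpret this result.

From the compounds shown here alone, whether an amine or a carboxylic acid at this position would stand apart from compound 1 remains open. So does whether fluoro against hydrogen reads the same with the aryl groups of compound 2 and compound 3.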